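A few compounds are considered here, and "the series" means these few. Any claim that something is new, unique, unknown or untested is made for them only; others in the source may bear on it.

Of the compounds shown here, two have been measured in a functional assay on IGROV-1 cells (Homo sapiens) for antiproliferative activity, read by sulforhodamine B assay, with a stated time of 48 h; on this read-out lower numbers stand for stronger inhibition of growth and higher numbers for weaker inhibition of growth. Compound 1, `Cc1nc(SCC(=O)Nc2nc(-c3ccc(Cl)cc3)cs2)n(Nc2ccccc2)c1C`, gives 3360 nM in this assay. Compound 2, `Cc1ccc(Nn2c(SCC(=O)Nc3nc(-c4ccccc4)cs3)nc(C)c2C)cc1`, gives 4590 nM in this assay. Compound 1 holds the lowest of the two numbers, yet compound 2 lies within the scatter of it, so no order between them can be claimed. For the measured compounds named here, compound 2 also differs from compound 1 in more than one place, so no single step between them is counted; their two values only show that the series so far sits close together.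

Compound 3, `COc1ccc(Nn2c(SCC(=O)Nc3nc(-c4ccc(Cl)cc4)cs3)nc(C)c2C)cc1`, is not yet measured. It differs from compound 1 by methoxy in place of hydrogen on an aromatic carbon. Going by the values given here, no measured pair shows this change on its own, so the size of its step is open. Since compound 1 gives 3360 nM and compound 2 gives 4590 nM in this assay, a small step in either direction, or none beyond the scatter, is expected. Compound 3 is therefore expected to give 3500 nM in this assay, within a range from 1200 nM to 10000 nM. That estimate means a step of a 1.0-fold higher number from compound 1 to compound 3 (0.02 log units; within the scatter), expected to stay within the scatter.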

Compound 3, concentration for 50% growth inhibition: 5670 nM
Compound 3: middle estimate off by 1.6-fold (0.21 log units), on the low side; the range from low to high includes it.
By their numbers in this assay, from the lowest: compounds 1, 2 and 3 (each within the scatter of the next).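

For the compounds shown here, replacing hydrogen with methoxy on an aromatic carbon, para to a large group, gives the first change that can be read in one place: in this assay, phenyl to 4-methoxyphenyl comes as a 1.7-fold higher number from compound 1 to compound 3 (0.23 log units; within the scatter). The earlier compounds shown here could not show this, since compound 1 and compound 2 differ in more than one place. This single pair shows that adding methoxy at this position, with its 2 heavy atoms and 1 hydrogen-bond acceptor, leaves the number within the scatter, and no measurement shown here accounts for the size of this step.

What the compounds shown leave open is whether this position stays as undemanding for other groups, such as an amine, a carboxylic acid or a longer alkoxy chain, since methoxy is the only group seen here in place of that hydrogen. Going by these compounds, it also remains open whether methoxy would give a step of similar size on another carbon of the same ring, or on a compound that differs from compound 1 elsewhere in its structure.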